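The compounds below may be only part of what the source reports. "The series", "measured", "known", "first", "only" and "open" are said of these compounds alone.

Measured compounds: compound 1 `CCN1C(=O)N(CC)C2C1NC(=S)N2/N=C/C=C/c1ccccc1` gives 2250 nM in a functional assay on RD cells (Homo sapiens) for inhibition, read by MTT assay, with a stated time of 72 h; a higher number here means a weaker inhibitor, a lower number a stronger inhibitor; compound 2 `CCN1C(=O)N(CC)C2C1NC(=S)N2/N=C/C=C/c1ccccc1[N+](=O)[O-]` gives 15300 nM; compound 3 `CCN1C(=O)N(CC)C2C1N=C(SC)N2/N=C/C=C/c1ccccc1` gives 24000 nM.

Compound 1 and compound 2 differ by nitro in place of hydrogen on an aromatic carbon, which gave a 6.8-fold higher number from compound 1 to compound 2 (0.83 log units; beyond the scatter). Compound 3 sits at the high end of the three numbers; its gap to compound 2 is within the scatter, its gap to compound 1 is beyond it. The difference between the core of compound 1 and the core of compound 3 is not broken down here.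

Compound 4 `CCN1C(=O)N(CC)C2C1N=C(SC)N2/N=C/C=C/c1ccccc1[N+](=O)[O-]` is not yet measured; it differs from compound 3 by nitro in place of hydrogen on an aromatic carbon, the same change as from compound 1 to compound 2, at the same kind of place. Compound 4 is therefore expected to show a 2.9-fold higher number from compound 3 to compound 4 (0.46 log units; beyond the scatter) in this assay, resting on a 6.8-fold higher number from compound 1 to compound 2 (0.83 log units; beyond the scatter). The starting point is compound 3, which gives 24000 nM. Compound 4 is estimated at 70000 nM, within 25000 nM to 200000 nM.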

Compound 4, half-maximal inhibitory concentration: 41900 nM
For compound 4 the middle estimate is 1.7-fold (0.22 log units) above the measured one; the measured number falls inside the stated range.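

On the core of compound 3, phenyl to 2-nitrophenyl gives a 1.7-fold higher number from compound 3 to compound 4 (0.24 log units; within the scatter). The change therefore does not carry over at the same size from one core to the other: the same change on two cores in this assay, a 6.8-fold higher number (0.83 log units; beyond the scatter) from compound 1 to compound 2 and a 1.7-fold higher number (0.24 log units; within the scatter) from compound 3 to compound 4, 3.9-fold (0.59 log units) apart, beyond the scatter of two such steps. With one pair on each core, this does not show why the size differs, or whether any other replacement on the phenyl would differ in the same way.

The compounds shown leave open whether an amine or a methoxy group in place of the same hydrogen would give steps that agree across the two cores. Also open, going by these compounds, is how a longer chain in place of the methyl on sulfur in compound 3 would read.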